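The source may report more compounds than this note shows. Statements on the series, on what has been measured and on what is new or still open speak of the compounds shown alone.

Compound 3 `CC(C)(C)n1ncc(OCc2nnc(-c3ccccc3)o2)c(Cl)c1=O` is the unsubstituted member of this small set: in a functional assay on the whole organism for inhibition, with Mythimna separata as the target, with a stated time of 5 days (on this read-out lower numbers stand for an effect already at smaller amounts and higher numbers for an effect only at larger amounts of compound), compound 3 gives 12200 nM, the second highest of the three numbers. Compound 2 `CC(C)(C)n1ncc(OCc2nnc(-c3ccc(F)cc3)o2)c(Cl)c1=O` gives 5200 nM, and compound 1 `CC(C)(C)n1ncc(OCc2nnc(-c3ccccc3Cl)o2)c(Cl)c1=O` gives 61200 nM.

The step to compound 4 `CC(C)(C)n1ncc(OCc2nnc(-c3ccc(Cl)cc3F)o2)c(Cl)c1=O` is 4-chloro-2-fluorophenyl in place of phenyl on an aromatic carbon. Two measured steps speak to it. The 2-chlorophenyl of compound 1 weighed on the result: a 5.0-fold lower number from compound 1 to compound 3 (0.70 log units; beyond the scatter). A fluoro on the 4-position, by contrast, helped: a 2.3-fold higher number from compound 2 to compound 3 (0.37 log units; beyond the scatter). Among the measured compounds shown here, compound 4 carries a halogen in each of these places, a chloro where compound 2 has its fluoro and a fluoro where compound 1 has its chloro, so the two measured steps pull in opposite directions, and there is no compound with two halogens on that ring to say which wins.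

Weighing the modest gain seen for compound 2 against the larger loss seen for compound 1, the expectation is a step of little size: a 1.2-fold lower number from compound 3 to compound 4 (0.09 log units; within the scatter) is expected, within the scatter of this assay. Compound 4 is therefore estimated at 10000 nM, with a range from 3000 nM to 35000 nM.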

Compound 4, half-maximal effective concentration: 10400 nM
Compound 4: the middle estimate sits 1.0-fold (0.02 log units) below what was measured; low and high end bracket the measured number.
By their numbers in this assay, from the lowest: compounds 2, 4 and 3 (each within the scatter of the next, the first and the last beyond it); then compound 1.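

In this assay, 4-chloro-2-fluorophenyl on this aromatic carbon of the five-membered ring cannot be told apart from phenyl (a 1.2-fold lower number from compound 3 to compound 4 (0.07 log units; within the scatter)) or from 4-fluorophenyl (a 2.0-fold higher number from compound 2 to compound 4 (0.30 log units; within the scatter)), although compound 2 and compound 3 do differ beyond the scatter. The only clear separation is from 2-chlorophenyl (a 5.9-fold lower number from compound 1 to compound 4 (0.77 log units; beyond the scatter)), so the loss seen with compound 1 does not carry over to every ring with a halogen, and this place accepts a phenyl with two halogens without a clear loss against phenyl itself. Nothing at hand says why these groups behave as they do.

The compounds shown do not separate the share of each halogen in compound 4, since 4-chlorophenyl and 2-fluorophenyl do not stand among them, and these two groups would be needed to tell whether either halogen alone accounts for the result. Also open, from the compounds shown here alone, is how this place responds to groups of another kind on the phenyl ring, such as methoxy, trifluoromethyl or an amine, or to a pyridine ring in place of phenyl.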